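A fluoro to chloro swap on the shared core

The source may hold more compounds than are shown below. What is called first, only, known or untested is meant among the compounds shown, and "the series" means these compounds.

In a functional assay on HL-60 cells (Homo sapiens) for antiproliferative activity, with a stated time of 48 h (a higher number here means that more compound is needed for the effect, a lower number that less compound is needed), compound 1 (`O=C(CCCCCCC(=O)Nc1cccc(F)c1)NO`) gives 1250 nM as its half-maximal effective concentration. In this assay, within the data shown here, compound 2 (`O=C(CCCCCCC(=O)Nc1ccc(C(F)(F)F)cc1)NO`) gives 1540 nM and this number lies within the scatter of the one for compound 1, so the two cannot be ranked.

Compound 3 (`O=C(CCCCCCC(=O)Nc1cccc(Cl)c1)NO`) has not yet been measured. It departs from compound 1 in one place (chloro in place of fluoro on an aromatic carbon) with chloro in place of fluoro on an aromatic carbon. Among the measured compounds shown here, no measured pair shows this change directly. In this assay no step beyond the scatter is expected in either direction, as the trifluoromethyl compound 2 at 1540 nM stays within the scatter of compound 1 despite its different group. The estimated step is a 1.1-fold lower number from compound 1 to compound 3 (0.04 log units; within the scatter) and it stays small. Compound 3 is expected at 1150 nM with an estimated range of 520 nM to 2500 nM in this measurement.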

Compound 3, half-maximal effective concentration: 2100 nM
Compound 3: the middle estimate sits 1.8-fold (0.26 log units) below what was measured, and the stated range covers the measured number.
By their numbers in this assay, from the lowest: compounds 1, 2 and 3 (each within the scatter of the next).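

In this assay, among these compounds, the swap gives a 1.7-fold higher number from compound 1 to compound 3 (0.23 log units; within the scatter), the first reading of a single change at this aromatic carbon, and it does not separate chloro from fluoro. For this one pair, then, the place meta to a large group takes either halogen without a step beyond the scatter, so compound 1 and compound 3 cannot be ranked. Nothing in the data shown explains the size of this step.

Going by these compounds, whether bromo, a methoxy group or an amine at this same place would give a step beyond the scatter remains open. So does whether chloro in place of fluoro would behave alike elsewhere on the aromatic ring, or on the shared core with a longer chain.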